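This account rests on a few compounds, and the source may have more. Where it says the series, first, only, none or still open, it means among the compounds named here.

Compound 1 `O=C(Nc1ccc(-c2c[nH]cn2)cc1)C1CCCN(Cc2ccc(F)c(F)c2)C1` gives > 20000 nM in a functional assay on A-375 cells (Homo sapiens) for antiproliferative activity (on this read-out lower numbers stand for stronger inhibition and higher numbers for weaker inhibition), and this is a limit of the assay rather than a number. Within the data shown here, compound 2 `O=C(Nc1ccc(-c2ccn[nH]2)cc1)C1CCCN(Cc2ccc(F)c(F)c2)C1` gives 520 nM, the only true number so far. Among the measured compounds shown here, the one measured step, an at least 38-fold lower number from compound 1 to compound 2 (1.58 log units; beyond the scatter), is large, and only the five-membered ring on the shared core changed along it. Compound 3 `O=C(Nc1ccc(-c2ccsc2)cc1)C1CCCN(Cc2ccc(F)c(F)c2)C1` changes that ring again: thiophen-3-yl in place of 1H-pyrazol-5-yl on an aromatic carbon. In words, thiophen-3-yl takes the place of 1H-pyrazol-5-yl. The measured step shows that this ring can matter greatly in this assay, but it says nothing directly about thiophen-3-yl. A large step in either direction therefore cannot be ruled out, though a modest move towards a higher number seems most likely. The expected change is a 2.3-fold higher number from compound 2 to compound 3 (0.36 log units; beyond the scatter). For compound 3 the estimated value is 1200 nM, with an expected range of 250 nM to 6000 nM.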

Compound 3, half-maximal inhibitory concentration: 950 nM
Estimate against measurement, compound 3: 1.3-fold (0.10 log units) above; the range from low to high includes it.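

Thiophen-3-yl in place of 1H-pyrazol-5-yl gives a 1.8-fold higher number from compound 2 to compound 3 (0.26 log units; within the scatter), so in this assay the hydrogen-bond donor of 1H-pyrazol-5-yl is not needed for a value in this range. Thiophen-3-yl in place of 1H-imidazol-4-yl gives an at least 21-fold lower number from compound 1 to compound 3 (1.32 log units; beyond the scatter), so the large step seen earlier is not tied to 1H-pyrazol-5-yl alone, and among these three rings only 1H-imidazol-4-yl stands apart. Compound 1 sits at a limit of the assay and not at a true number, so its steps give only a minimum size: the limit of > 20000 nM in this assay, at which 1 of the 3 values shown sits.

On these data alone, it remains open whether a six-membered ring such as pyridine, or a simple amine or carboxylic acid, would be tolerated at this place. As far as these compounds go, it also remains open whether this ranking of rings would hold if the rest of the shared core were changed.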